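The source may hold more compounds than are shown below. What is called first, only, known or untested is meant among the compounds shown, and "the series" means these compounds.

Among three compounds measured in an assay on mitochondria (strain BALB/c) for inhibition of glycerol-3-phosphate acyltransferase 1, mitochondrial (Mus musculus), read by scintillation counting, with a stated time of 10 min (on this read-out higher numbers stand for weaker inhibition and lower numbers for stronger inhibition), compound 2 `CCCCCCCCS(=O)(=O)Nc1ccc(-c2ccc(CCCC)cc2)cc1C(=O)O` gives 9000 nM, the lowest of the three numbers. Compound 1 `CCCCCCCCS(=O)(=O)Nc1cc(-c2ccccc2Cl)ccc1C(=O)O` gives 26900 nM, and compound 3 `CCCCCCCCS(=O)(=O)Nc1ccc(-c2ccc(-c3ccccc3)cc2)cc1C(=O)O` gives 29100 nM. Among the measured compounds shown here, the one step that bears on the question is a 3.2-fold higher number from compound 2 to compound 3 (0.51 log units; beyond the scatter), in which the butyl on the outer ring was swapped for a phenyl. Compound 4 `CCCCCCCCS(=O)(=O)Nc1ccc(-c2ccccc2O)cc1C(=O)O` differs from compound 2 by 2-hydroxyphenyl in place of 4-butylphenyl on an aromatic carbon. That measured step already went toward weaker inhibition, and the new change removes the butyl altogether while bringing in a hydroxy group, so a step of similar size toward weaker inhibition in this assay is expected. For compound 4 the estimated value is 30000 nM, with a range from 10000 nM to 90000 nM. This expectation amounts to a 3.3-fold higher number from compound 2 to compound 4 (0.52 log units; beyond the scatter).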

Compound 4, half-maximal inhibitory concentration: 61700 nM
Estimate against measurement, compound 4: 2.1-fold (0.31 log units) below, within the range that was stated.
By their numbers in this assay, from the lowest: compound 2; then compounds 1 and 3 (each within the scatter of the next); then compound 4.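

In this assay, putting 2-hydroxyphenyl in place of 4-butylphenyl on this aromatic carbon, meta to a carboxy group, gives a 6.9-fold higher number from compound 2 to compound 4 (0.84 log units; beyond the scatter), a move toward weaker inhibition. This is a second replacement of the butyl-bearing ring that weakens inhibition, after a 3.2-fold higher number from compound 2 to compound 3 (0.51 log units; beyond the scatter). Nothing shown explains the change in inhibition.

Going by these compounds, the butyl leaves and the hydroxy enters in one change, so their separate contributions remain unknown. Also open, on these data alone, is how a hexyl chain in place of the butyl, or an amine or methoxy group in place of the hydroxy, would read out.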